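Dimethylamino for pyrrolidin-1-yl in a compound at the limit

The compounds below may be only part of what the source reports. "The series", "measured", "known", "first", "only" and "open" are said of these compounds alone.

Measured so far in a functional assay on the whole organism for antagonist activity, with Mus musculus as the target (on this read-out lower numbers stand for an effect already at smaller amounts and higher numbers for an effect only at larger amounts of compound), for each compound
Compound 1 `Cc1cncn1CC#CCN1C(=O)CCC1C` gives 1.4 mg/kg as a number
Compound 2 `COC(=O)N(C)CC#CCN1CCCC1` gives > 10 mg/kg as a limit
Compound 3 `COC(=O)N(C)C(C)C#CCN1CCCC1` gives > 100 mg/kg as a limit

Compound 3 stands with a limit rather than a number in this assay, and the same holds for compound 2, so only compound 1 offers a true figure.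

Compound 4 `COC(=O)N(C)C(C)C#CCN(C)C` differs from compound 3 in one place, (dimethylamino in place of pyrrolidin-1-yl on a saturated chain carbon bound to a triple-bonded carbon), where dimethylamino takes the place of pyrrolidin-1-yl on a saturated chain carbon bound to a triple-bonded carbon.

Going by the values given here, the one measured step is a step that the two limits leave unreadable from compound 2 to compound 3, which puts methyl in place of hydrogen on a saturated chain carbon bound to an amide-type nitrogen and a triple-bonded carbon. Its two ends are the limit of > 10 mg/kg in this assay, at which 1 of the 3 values shown sits, and (the limit of > 100 mg/kg in this assay, at which 1 of the 3 values shown sits), so it has no readable size. Among the compounds with values here, no measured step exchanges pyrrolidin-1-yl for another group.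

Within the data shown here, compound 4 keeps the methyl of compound 3, and the limit of compound 3 at > 100 mg/kg is therefore the only guide. The expected a number no higher from compound 3 to compound 4 (the limit leaves the size open) is a rough estimate with no clear direction, and a further limit would be no surprise. The estimate for compound 4 is 100 mg/kg, expected to lie from 30 mg/kg to 300 mg/kg when tested in this assay once more.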

Compound 4, dose for half-maximal effect: > 100 mg/kg
Compound 4 gave a limit, no number; the forecaster's own chance of this, stated with the estimate: 75%; the middle value lies on the limit itself.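

In this assay, compound 3 and compound 4 both end at a limit rather than a number, so the exchange of pyrrolidin-1-yl for dimethylamino between them has no readable size. The compounds shown leave open where the true values of these two compounds lie, and whether this exchange alters the effect at all.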